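A Larger Group Enters Where a Hydroxy Group Leaves

The source may report more compounds than this note shows. Statements on the series, on what has been measured and on what is new or still open speak of the compounds shown alone.

Compound 1 `CC(C)(C)c1ccc(C(=O)N2CCC3(CC2)C(=O)N(CC(=O)N2CCCC(C(N)=O)C2)CN3c2ccccc2)cc1` — 16900 nM
Compound 2 `CC(C)(C)c1ccc(C(=O)N2CCC3(CC2)C(=O)N(CC(=O)NCCC(=O)O)CN3c2ccccc2)cc1` — 11400 nM
Compound 3 `CC(C)(C)c1ccc(C(=O)N2CCC3(CC2)C(=O)N(CC(=O)N2CCC(O)CC2)CN3c2ccccc2)cc1` — 4700 nM

All three compounds were measured in an assay on HEK293 cells for displacement of a labelled ligand from NPC1-like intracellular cholesterol transporter 1 (Homo sapiens) (a lower number here means a stronger inhibitor, a higher number a weaker inhibitor), and share one core, differing only in the group on the carbonyl carbon. Compound 3 gives the lowest number of the three: a 3.6-fold lower number from compound 1 to compound 3 (0.56 log units; beyond the scatter) and a 2.4-fold lower number from compound 2 to compound 3 (0.38 log units; beyond the scatter), while a 1.5-fold lower number from compound 1 to compound 2 (0.17 log units; within the scatter). Going by the values given here, every change at this position so far has shifted the number only modestly.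

Compound 4 `CCc1nn(CC)c(C2CCN(C(=O)CN3CN(c4ccccc4)C4(CCN(C(=O)c5ccc(C(C)(C)C)cc5)CC4)C3=O)CC2)c1C` is not yet measured. Compared with compound 3 it differs in one place: 1,3-diethyl-4-methyl-1H-pyrazol-5-yl in place of hydroxy on a saturated ring carbon. Among the compounds with values here, no measured pair covers a change of this kind; the three steps at the same position suggest that alterations here move the result by small to modest amounts, and they are the only guide available. Compound 4 is therefore expected to stay close to compound 3 in this assay, with the step of a 1.3-fold lower number from compound 3 to compound 4 (0.13 log units; within the scatter) estimated as small and of uncertain direction. The number expected for compound 4 is 3500 nM, within a range from 900 nM to 14000 nM.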

Compound 4, half-maximal inhibitory concentration: 2500 nM
For compound 4 the middle estimate is 1.4-fold (0.15 log units) above the measured one, within the range that was stated.
By their numbers in this assay, from the lowest: compounds 4 and 3 (each within the scatter of the next); then compounds 2 and 1 (each within the scatter of the next).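

On the saturated ring carbon of compound 3, hydroxy with its 1 heavy atom gives way to 1,3-diethyl-4-methyl-1H-pyrazol-5-yl with its 10 heavy atoms and five-membered aromatic ring, and in this assay this yields a 1.9-fold lower number from compound 3 to compound 4 (0.27 log units; within the scatter). The earlier compounds shown here differed in the whole group on the carbonyl carbon, whereas this pair keeps the six-membered ring and shows that a much larger group on it, with 0 hydrogen-bond donors in place of 1, produces no step beyond the scatter. Nothing available accounts for why the number holds across so large an exchange. As far as these compounds go, it remains open whether an amine or a carboxylic acid on the same ring carbon would also stay this close to compound 3. Also open, from the compounds shown here alone, is whether a pyrazole lacking the two ethyl groups would do the same.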